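This account rests on a few compounds, and the source may have more. Where it says the series, first, only, none or still open, it means among the compounds named here.

Compound 1 `Cc1cccc(/C=N/c2ccc(OCc3ccccc3)cc2)c1O` gives 15500 nM
Compound 2 `COc1cccc(/C=N/c2ccc(OCc3ccccc3)cc2)c1O` gives 6500 nM
Compound 3 `COc1ccc(O)c(/C=N/c2ccc(OCc3ccccc3)cc2)c1` gives 10700 nM

In an assay on isolated protein for inhibition of Amine oxidase [flavin-containing] B (Homo sapiens), read by fluorescence and Amplex Red, with stated times of 15 min and 20 min (a higher number here means a weaker inhibitor, a lower number a stronger inhibitor), compound 3 gives 10700 nM. Against compound 1 and compound 2 this value lies within the usual scatter of both, so the three numbers establish no order among them. The step to compound 4 `Oc1ccccc1/C=N/c1ccc(OCc2ccccc2)cc1` is hydrogen in place of methoxy on an aromatic carbon. Only one measured step exists among these compounds, a 2.4-fold lower number from compound 1 to compound 2 (0.38 log units; beyond the scatter), and it concerns a change at another place and of another kind, so it bears little on the loss of a methoxy group. With nothing that speaks directly to this change, no step beyond the scatter is expected in this assay. Compound 4 is therefore expected to give 12000 nM, with a range from 5000 nM to 30000 nM. The expected step is a 1.1-fold higher number from compound 3 to compound 4 (0.05 log units; within the scatter), within the scatter.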

Compound 4, half-maximal inhibitory concentration: 25100 nM
Estimate against measurement, compound 4: 2.1-fold (0.32 log units) below; the measured number falls inside the stated range.
By their numbers in this assay, from the lowest: compounds 2, 3, 1 and 4 (each within the scatter of the next, the first and the last beyond it).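

Removing the methoxy group weakens inhibition in this assay wherever the group stood, beyond the scatter in both cases (a 2.3-fold higher number from compound 3 to compound 4 (0.37 log units; beyond the scatter)) and (a 3.9-fold higher number from compound 2 to compound 4 (0.59 log units; beyond the scatter)). Hydrogen in place of methyl, by contrast, stays within the scatter (a 1.6-fold higher number from compound 1 to compound 4 (0.21 log units; within the scatter)), so among these compounds only methoxy separates from hydrogen. Nothing measured here gives a reason for this.

On these data alone, whether ethoxy, an amine or a fluorine at this aromatic carbon would match methoxy remains open. So does whether a second methoxy group on the same ring would add to the effect.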